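The source may hold more compounds than are shown below. What is called first, only, known or untested is meant among the compounds shown, and "the series" means these compounds.

The series rests on a shared core that carries a trimethoxyphenyl group and a 4-methoxyphenyl group, and varies the amide nitrogen. Compound 1 `COc1ccc(-n2nc(C(N)=O)nc2-c2cc(OC)c(OC)c(OC)c2)cc1` bears a free amide and in a functional assay on the whole organism for inhibition, with Rattus norvegicus as the target, read by paw edema, with stated times of 30 min and 3 h, at a dose of 0.28 mmol/kg by the oral route (a higher number here means more inhibition at the dose given (going by the name of the read-out), a lower number less inhibition), compound 1 gives 72%. Compound 2 `COc1ccc(NC(=O)c2nc(-c3cc(OC)c(OC)c(OC)c3)n(-c3ccc(OC)cc3)n2)cc1` carries a 4-methoxyphenyl on that nitrogen, and in this assay compound 2 gives 67%; the step of a number 5 percentage points lower from compound 1 to compound 2 (within the scatter) lies within the scatter. Compound 3 `COc1ccc(-n2nc(C(=O)Nc3ccc(C)cc3)nc2-c2cc(OC)c(OC)c(OC)c2)cc1` carries a 4-methylphenyl instead, and in this assay compound 3 gives 60%. Compound 3 thus stands lowest of the three numbers: the step of a number 12 percentage points lower from compound 1 to compound 3 (beyond the scatter) is beyond the scatter, while the step of a number 7 percentage points lower from compound 2 to compound 3 (within the scatter) is within it.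

Compound 4 `COc1ccc(-n2nc(C(=O)Nc3cccc(F)c3)nc2-c2cc(OC)c(OC)c(OC)c2)cc1` is the next member. Its change from compound 3 is 3-fluorophenyl in place of 4-methylphenyl on an amide-type nitrogen. Among the compounds with values here, no measured step swaps one aryl for another on this nitrogen; the nearest comparison is the step from compound 2 to compound 3, which exchanged substituents on such an aryl group and stayed within the scatter, and both aryl amides sit near each other. On that basis no step beyond the scatter is expected for the change to compound 4, that is no change at the digits printed from compound 3 to compound 4 (within the scatter). Compound 4 is therefore estimated at 60%, with a range from 48% to 72%.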

Compound 4, a percentage reported as inhibition, in the whole organism at one dose (the size of the read-out at that dose, not a potency): 72%
For compound 4 the middle estimate is 12 percentage points below the measured one, and the stated range covers the measured number.
By their numbers in this assay, from the lowest: compounds 3, 2, 1 and 4 (each within the scatter of the next, the first and the last beyond it).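

In this assay the aryl group on the amide nitrogen proves able to move the number on its own: the step, a number 12 percentage points higher from compound 3 to compound 4 (beyond the scatter), shows an exchange of one aryl group for another going beyond the scatter, which the earlier exchange of substituents on such an aryl group had not done. Within the data shown here, a group on this nitrogen is also not tied to a result apart from the free amide, since the step, no change at the digits printed from compound 1 to compound 4 (within the scatter), leaves 3-fluorophenyl and hydrogen unseparated, and the step, a number 5 percentage points higher from compound 2 to compound 4 (within the scatter), does the same for 3-fluorophenyl and 4-methoxyphenyl, so that among the aryl amides only the pair of compound 3 and compound 4 is told apart. No measurement bearing on why these groups differ is available.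

The compounds shown include neither 4-fluorophenyl nor 3-methylphenyl on this nitrogen, so the contribution of the fluorine cannot be separated from that of where the substituent sits on the ring. They also leave open what a non-aromatic group such as cyclohexyl, a longer chain such as butyl, or a second methyl-bearing aryl group such as 3,4-dimethylphenyl would give here.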